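A Chloro Group Exchanged for Methoxy in a Cytotoxicity Series

This account rests on a few compounds, and the source may have more. Where it says the series, first, only, none or still open, it means among the compounds named here.

Of the compounds shown here, three have been measured in a functional assay on ECa-109 cells (Homo sapiens) for cytotoxicity, read by MTT assay, with a stated time of 72 h; a lower number here means a stronger inhibitor, a higher number a weaker inhibitor. Compound 1, `O=C(/C=C/c1ccccc1)NNC(=O)c1ccccc1O`, gives 41400 nM. Compound 2, `COCOc1ccc(/C=C/C(=O)N2CCN(Cc3ccc(Cl)c(Cl)c3)CC2)cc1OCOC`, gives 7400 nM. Compound 3, `O=C(COC(=O)/C=C/c1ccc(O)c(O)c1)Nc1ccc(Cl)cc1`, gives 175000 nM, the highest of the three numbers and therefore the weakest inhibitor of this set; compound 1 stands nearest to it, and compound 2 furthest, both gaps reaching beyond the scatter of repeated measurements.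

Compound 4, `COc1ccc(NC(=O)COC(=O)/C=C/c2ccc(O)c(O)c2)cc1`, has not yet been tested in this assay. It differs from compound 3 in one place: methoxy in place of chloro on an aromatic carbon. Nothing else in the structure changes.

Among the compounds with values here, no pair of measured compounds in this set differs by this kind of exchange, so there is no measured step to lean on. In such cases a modest shift is the more common outcome, and the direction cannot be read from the three values shown. The step from compound 3 to compound 4 is therefore expected to be small, estimated at a 1.2-fold lower number from compound 3 to compound 4 (0.07 log units; within the scatter), likely not beyond the scatter. Compound 4 is accordingly expected to give about 150000 nM in this assay, with a range from 50000 nM to 450000 nM.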

Compound 4, half-maximal inhibitory concentration: 190000 nM
Estimate against measurement, compound 4: 1.3-fold (0.10 log units) below; the range from low to high includes it.
By their numbers in this assay, from the lowest: compound 2; then compound 1; then compounds 3 and 4 (each within the scatter of the next).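

In this assay, within the data shown here, the exchange of 4-chlorophenyl for 4-methoxyphenyl gives a 1.1-fold higher number from compound 3 to compound 4 (0.04 log units; within the scatter) and is the first step in this set that can be read between two measured compounds. At this position, on an aromatic carbon para to a large group, the assay does not separate the two groups: compound 3 at 175000 nM and compound 4 at 190000 nM lie within the scatter of each other, even though methoxy brings one more heavy atom and a hydrogen-bond acceptor. No measurement among the compounds shown speaks to the reason for this result.

Chloro and methoxy are the only groups seen at this position, so it remains open whether an amine, a carboxylic acid or a longer alkoxy chain placed there would also leave the number within the scatter. On these data alone, it is also open whether methoxy in place of chloro on an aromatic carbon of compound 2, which stands on a different core, would give a similarly small step.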